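The source may hold more compounds than are shown below. What is called first, only, known or untested is meant among the compounds shown, and "the series" means these compounds.

Of the compounds shown here, three of a shared core have been measured in an ADME assay on liver (Mesocricetus auratus) for metabolic stability, using microsomes; on this read-out lower numbers stand for slow clearance and higher numbers for fast clearance. Compound 1 `O=C(Nc1cc(-c2ccccn2)n[nH]1)N1CCC(Oc2ccccc2)CC1` gives 98.5 mL.min-1.g-1 in this assay, compound 2 `O=C(Nc1cc(-c2ccccn2)n[nH]1)N1CCC(Oc2ccccn2)CC1` gives 67.3 mL.min-1.g-1, and compound 3 `O=C(Nc1cc(-c2ccccn2)n[nH]1)N1CCC(c2ccc(F)cc2)CC1` gives 272 mL.min-1.g-1. Compound 3 therefore stands highest of the three: its number lies a measurable distance above both others, as seen in the steps of a 2.8-fold higher number from compound 1 to compound 3 (0.44 log units; beyond the scatter) and a 4.0-fold higher number from compound 2 to compound 3 (0.61 log units; beyond the scatter), whereas the step of a 1.5-fold lower number from compound 1 to compound 2 (0.17 log units; within the scatter) stays within the scatter.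

Compound 4 `O=C(Nc1cc(-c2ccccn2)n[nH]1)N1CCC(c2cccc(Cl)c2)CC1` follows from compound 3 by one change: 3-chlorophenyl in place of 4-fluorophenyl on a saturated ring carbon. For the measured compounds named here, none of the measured steps exchanges one halogen-bearing phenyl for another on the saturated ring carbon; the two steps that reach compound 3 concern the loss of an oxygen-linked ring, and the step between compound 1 and compound 2 concerns a ring on that oxygen. Going by the values given here, the account thus has no direct precedent for this change, and the nearest analogy, the within-scatter step between compound 1 and compound 2, points to a small movement. For compound 4 the step of a 1.1-fold higher number from compound 3 to compound 4 (0.04 log units; within the scatter) is expected to stay within the scatter. Compound 4 is accordingly estimated at 300 mL.min-1.g-1 in this assay, with a range from 150 mL.min-1.g-1 to 600 mL.min-1.g-1.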

Compound 4, intrinsic clearance in microsomes: 63.5 mL.min-1.g-1
Compound 4: the middle estimate sits 4.7-fold (0.67 log units) above what was measured; the measured number lies below the stated range.
By their numbers in this assay, from the lowest: compounds 4, 2 and 1 (each within the scatter of the next); then compound 3.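

In this assay, the group on the saturated ring carbon proves sensitive to a change that leaves the counts untouched: the step is a 4.3-fold lower number from compound 3 to compound 4 (0.63 log units; beyond the scatter), beyond the scatter, although 4-fluorophenyl and 3-chlorophenyl have the same number of heavy atoms and the same single aromatic ring of carbon only. Compound 3 alone had linked a halogen-bearing phenyl on that carbon to the highest number, but compound 4 goes against that pattern, with the steps of a 1.1-fold lower number from compound 2 to compound 4 (0.03 log units; within the scatter) and a 1.6-fold lower number from compound 1 to compound 4 (0.19 log units; within the scatter) both within the scatter, so a halogen-bearing phenyl without the oxygen link does not in itself bring a high number. Nothing available bears on why the two halogen-bearing phenyl groups differ so much in this read-out.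

This step changes the halogen and its ring placement together, and the compounds shown cannot separate the two; 3-fluorophenyl and 4-chlorophenyl would do so. They also leave open how an unsubstituted phenyl or a 3-methoxyphenyl group on the same carbon would compare with compound 3 and compound 4.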